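This account rests on a few compounds, and the source may have more. Where it says the series, first, only, none or still open, it means among the compounds named here.

Compound 1 `CC(=O)N1CCc2oc(=O)n(C(=O)NCCCCc3ccccc3)c2C1`, compound 2 `CN1CCN(c2ccc3c(c2)oc(=O)n3C(=O)NCCCCc2ccccc2)C(=O)C1` and compound 3 `CC(C)CNC(=O)n1c(=O)oc2cc(C3CCN(C)CC3)ccc21` share one core and have each been tested in an assay on HEK293 cells for inhibition of acid ceramidase (Homo sapiens), read by fluorescence, with stated times of 10 min and 3 h; a lower number here means a stronger inhibitor, a higher number a weaker inhibitor. Compound 1 gives 293 nM, compound 3 gives 166 nM, and compound 2 gives 52 nM, the lowest of the three numbers, with compound 3 nearest and compound 1 furthest, both beyond the scatter. Compound 4 `CCN1CCC(c2ccc3c(c2)oc(=O)n3C(=O)NCCCCc2ccccc2)CC1` has not yet been measured in this assay. It differs from compound 2 in one place: 1-ethylpiperidin-4-yl in place of 4-methyl-2-oxopiperazin-1-yl on an aromatic carbon. Within the data shown here, no measured pair shows this change on its own, so its direction is uncertain, and the step from compound 2 to compound 4 is expected to be small, a 1.3-fold higher number from compound 2 to compound 4 (0.10 log units; within the scatter), at most on the edge of the scatter. Compound 4 is therefore estimated at 65 nM, within a range from 20 nM to 200 nM.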

Compound 4, half-maximal inhibitory concentration: 92 nM
Compound 4: the middle estimate sits 1.4-fold (0.15 log units) below what was measured; measured number inside the range.
By their numbers in this assay, from the lowest: compounds 2, 4, 3 and 1 (each within the scatter of the next, the first and the last beyond it).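

In this assay, the aromatic carbon of compound 2 accepts 1-ethylpiperidin-4-yl in place of 4-methyl-2-oxopiperazin-1-yl with a 1.8-fold higher number from compound 2 to compound 4 (0.25 log units; within the scatter). At this position, then, the two groups are not separated, although the entering ring has one hetero atom rather than two and no double bond outside aromatic rings. Among these compounds, this pair is the first to isolate a change at this place, and it shows that the carbonyl-bearing piperazinone ring is not required here for a number in this range.

On these data alone, how a carboxylic acid or an open-chain amine on the same aromatic carbon would fare remains open. Nothing available explains why these two groups give such similar numbers.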